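Removing a Chloro Group in a Weakly Cytotoxic Series

This account rests on a few compounds, and the source may have more. Where it says the series, first, only, none or still open, it means among the compounds named here.

Three compounds have been measured in a functional assay on Ehrlich cells (Mus musculus) for cytotoxicity, tested at 10 ug/mL; on this read-out lower numbers stand for a weaker effect and higher numbers for a stronger effect at the one concentration tested:
Compound 1, `COc1cc(N2C(N)=C(C#N)C(c3c(O)ccc4ccccc34)C3=C2CC(C)(C)CC3=O)cc(OC)c1OC`, gives 2%.
Compound 2, `COc1cc(N2C(N)=C(C#N)C(c3cccc([N+](=O)[O-])c3)C3=C2CC(C)(C)CC3=O)cc(OC)c1OC`, gives 5%.
Compound 3, `COc1cc(N2C(N)=C(C#N)C(c3ccccc3Cl)C3=C2CC(C)(C)CC3=O)cc(OC)c1OC`, gives 10%.

Compound 3 holds the highest of these three numbers, yet every gap to it lies within the usual scatter: a number 5 percentage points higher from compound 2 to compound 3 (within the scatter) and a number 8 percentage points higher from compound 1 to compound 3 (within the scatter). The remaining pair is no different, a number 3 percentage points higher from compound 1 to compound 2 (within the scatter). In other words, swapping the whole group on the saturated ring carbon, from 2-hydroxynaphthalen-1-yl to 3-nitrophenyl to 2-chlorophenyl, has not produced any shift that can be told apart from noise in this assay.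

Compound 4, `COc1cc(N2C(N)=C(C#N)C(c3ccccc3)C3=C2CC(C)(C)CC3=O)cc(OC)c1OC`, is compound 3 with a smaller change: hydrogen in place of chloro on an aromatic carbon. Among the measured compounds shown here, none of the measured steps removes only a chloro; all three exchanged the entire aryl group, and all three stayed within the scatter. There is therefore no evidence in these data for a step beyond the scatter in this assay, and the expected change is a number 4 percentage points lower from compound 3 to compound 4 (within the scatter). Compound 4 is estimated at 6%, with a range from 0% to 15%.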

Compound 4, a percentage reported as activity, at one concentration (the size of the read-out at that concentration, not a potency): 0%
The estimate for compound 4 lay 6 percentage points above the measured number; low and high end bracket the measured number.
By their numbers in this assay, from the lowest: compounds 4, 1, 2 and 3 (each within the scatter of the next).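

Removing only the chloro, the one atom ortho to a large group on the aromatic ring, gives in this assay a number 10 percentage points lower from compound 3 to compound 4 (within the scatter), so even this smallest change at the position cannot be told apart from noise. The plain phenyl ring of compound 4 also serves as an unsubstituted reference for the other aryl groups: hydrogen in place of nitro gives a number 5 percentage points lower from compound 2 to compound 4 (within the scatter), and phenyl in place of 2-hydroxynaphthalen-1-yl gives a number 2 percentage points lower from compound 1 to compound 4 (within the scatter), so neither the nitro group nor the larger 2-hydroxynaphthalen-1-yl group can be distinguished from the plain phenyl ring in this read-out. The data offer no independent measurement that would explain any of these small differences.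

The compounds shown leave open whether a different group on this aromatic ring, such as an amine, a carboxylic acid or a longer chain, would give a step beyond the scatter. They also leave open whether changes elsewhere on the shared core would matter more than changes to this aryl group, and, with only one concentration tested, how any of these compounds would behave at higher concentrations.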